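The source may report more compounds than this note shows. Statements on the series, on what has been measured and on what is new or still open speak of the compounds shown alone.

In a physicochemical assay for lipophilicity, using the shake flask method, measured as octanol-water partition, with a stated time of 30 min, at pH 7.4 (a lower number here means a more polar compound, a higher number a more lipophilic compound), compound 3 (`Cc1cc(-c2ccc(CCC(=O)O)cc2)cc2c1cnn2-c1ccccn1`) gives 2.6 as the second highest of three measured numbers. Compound 1 (`Cc1nn(-c2ccccn2)c2cc(-c3ccc(CCC(=O)O)cc3C#N)ccc12`) sits lower at 2.2 and compound 2 (`COc1nn(-c2ccccn2)c2cc(-c3ccc(CCC(=O)O)cc3)ccc12`) sits higher at 3.3 on the same scale, and both gaps from compound 3 lie beyond the usual scatter of repeat measurements.

Compound 4 (`N#Cc1cc(-c2ccc(CCC(=O)O)cc2)cc2c1cnn2-c1ccccn1`) has not been measured yet. It has cyano in place of methyl on an aromatic carbon of compound 3 (cyano in place of methyl on an aromatic carbon). Among the compounds with values here, no two measured compounds differ in one place only, so no direct measured step is available as a guide. Within the data shown here, the nearest hint is weak: compound 1 is the only measured compound with a cyano group, and it gives 2.2 as the lowest number, although it differs from compound 3 in more than one place.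

A downward move in this assay is therefore expected, and the estimated step of a number 0.60 log units lower from compound 3 to compound 4 (beyond the scatter) would lie beyond the scatter. The estimate for compound 4 is 2 with an expected range from 1.6 to 2.4 when it is measured.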

Compound 4, distribution coefficient: 2.2
For compound 4 the middle estimate is 0.20 log units below the measured one; the range from low to high includes it.
By their numbers in this assay, from the lowest: compounds 1 and 4 (each within the scatter of the next); then compound 3; then compound 2.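

In this assay, within the data shown here, cyano in place of methyl on this aromatic carbon, ortho to a fused ring, gives a number 0.40 log units lower from compound 3 to compound 4 (beyond the scatter) and is the first change that can be read on its own. Compound 1 also carries a cyano group, but it differs from the other compounds in more than one place, so it could not isolate this swap. Nothing measured here explains the direction or the size of this step.

The compounds shown leave open how other groups, such as an amine or a single fluorine atom, would read at this same carbon. Among these compounds, they also leave open whether the swap from methyl to cyano would give a step of similar size elsewhere on the shared core, with only this one pair available.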